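Same Small Change, Seen Once, Expected Again

A few compounds are considered here, and "the series" means these few. Any claim that something is new, unique, unknown or untested is made for them only; others in the source may bear on it.

Measured compounds:
- compound 1, `COc1ccc2nc(NC(=O)CCCCC(=O)NO)sc2c1`, gives 5.91 ug/mL in a functional assay on MCF7 cells (Homo sapiens) for cytotoxicity; a lower number here means a stronger inhibitor, a higher number a weaker inhibitor
- compound 2, `CCOc1ccc2nc(NC(=O)CCCCC(=O)NO)sc2c1`, gives 8.72 ug/mL
- compound 3, `CCOc1ccc2nc(NC(=O)CCCCCCC(=O)NO)sc2c1`, gives 11.6 ug/mL

Compound 4, `COc1ccc2nc(NC(=O)CCCCCCC(=O)NO)sc2c1`, has not yet been measured in this assay. It differs from compound 3 in one place: hydrogen in place of methyl on a saturated chain carbon bound to an oxygen on an aromatic ring. The same change links compound 2 to compound 1: hydrogen in place of methyl on a saturated chain carbon bound to an oxygen on an aromatic ring, and the step it made there was a 1.5-fold lower number from compound 2 to compound 1 (0.17 log units; within the scatter). The two cores differ as follows: 2-(hydroxycarbamoyl)ethyl in place of hydroxycarbamoyl on a saturated chain carbon, four bonds along the chain from a carbonyl carbon, and that step was a 1.3-fold higher number from compound 2 to compound 3 (0.12 log units; within the scatter). A step of similar size is expected here, a 1.5-fold lower number from compound 3 to compound 4 (0.16 log units; within the scatter), because the earlier step was a 1.5-fold lower number from compound 2 to compound 1 (0.17 log units; within the scatter) and stayed within the scatter. Compound 4 is therefore estimated at 8 ug/mL, with a likely range from 4 ug/mL to 16 ug/mL.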

Compound 4, half-maximal inhibitory concentration: 1.85 ug/mL
Compound 4: middle estimate off by 4.3-fold (0.64 log units), on the high side; measured number below the stated range.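

In this assay, going from ethoxy to methoxy on the longer chain gave a 6.3-fold lower number from compound 3 to compound 4 (0.80 log units; beyond the scatter), so the size of this step did not carry over from the core with the shorter chain: the same change on two cores in this assay, a 1.5-fold lower number (0.17 log units; within the scatter) from compound 2 to compound 1 and a 6.3-fold lower number (0.80 log units; beyond the scatter) from compound 3 to compound 4, 4.2-fold (0.63 log units) apart, beyond the scatter of two such steps Read the other way, the longer chain gave a 3.2-fold lower number from compound 1 to compound 4 (0.50 log units; beyond the scatter) with methoxy present, a different outcome from the one seen with ethoxy: the same change on two cores in this assay, a 1.3-fold higher number (0.12 log units; within the scatter) from compound 2 to compound 3 and a 3.2-fold lower number (0.50 log units; beyond the scatter) from compound 1 to compound 4, 4.2-fold (0.63 log units) apart, beyond the scatter of two such steps In these four compounds, then, the two changes do not act independently, but this rests on a single comparison and shows neither why that happens nor whether it holds on other cores.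

Still open, on these data alone, is whether the drop depends on this exact chain length. An even longer chain, or a hydroxy group or chlorine in place of methoxy, could test how far it extends.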